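Anilide Extension of a Benzimidazole Carboxamide: Vero Cytotoxicity

The compounds below may be only part of what the source reports. "The series", "measured", "known", "first", "only" and "open" are said of these compounds alone.

Measured compounds:
compound 1, `NC(=O)c1cccc2[nH]c(-c3ccccn3)nc12`, 224 uM
compound 2, `NC(=O)c1cccc2[nH]c(-c3cccnc3)nc12`, 77.7 uM

Both compounds were tested in an ADME assay on Vero cells (Chlorocebus sabaeus) for cytotoxicity; a higher number here means that more compound is tolerated, a lower number that less compound is tolerated. Compound 2 stands lowest of the two, with compound 1 above it by a 2.9-fold lower number from compound 1 to compound 2 (0.46 log units; beyond the scatter). Compound 3, `O=C(Nc1ccccc1)c1cccc2[nH]c(-c3cccnc3)nc12`, has not yet been measured there. It differs from compound 2 by phenyl in place of hydrogen on an amide-type nitrogen; cut one bond further out, the change reads amino to anilino. Among the compounds with values here, no measured step touches the amide nitrogen; the only step at hand concerns the pyridyl ring and was modest. The direction of a change at the amide is therefore not anchored by these data. A modest move downward is expected, as a step of a 1.7-fold lower number from compound 2 to compound 3 (0.24 log units; within the scatter) from compound 2 is estimated. Compound 3 is expected to give about 45 uM, within a range from 15 uM to 140 uM.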

Compound 3, half-maximal toxic concentration: 34.2 uM
Beside the measured number, compound 3's estimate is 1.3-fold (0.12 log units) above it; the measured number falls inside the stated range.
By their numbers in this assay, from the lowest: compound 3; then compound 2; then compound 1.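

In this assay, the amide nitrogen now has a measured step of its own: phenyl in place of hydrogen gives a 2.3-fold lower number from compound 2 to compound 3 (0.36 log units; beyond the scatter) and so shows that this position, untouched by the earlier pair, does move the number. The direction at this place is now anchored, though only for anilino in place of amino and only on the pyridin-3-yl compound. Nothing measured here bears on why the number moves this way.

Going by these compounds, whether the same change on the pyridin-2-yl compound, compound 1, would give a step of like direction and size remains open. Also open, on these data alone, is whether the step needs the aromatic ring itself or would also follow from a methyl group, a longer alkyl chain or a benzyl group on the amide nitrogen.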